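Ethylsulfanyl to Methoxy: What to Expect for Compound 3

A few compounds are considered here, and "the series" means these few. Any claim that something is new, unique, unknown or untested is made for them only; others in the source may bear on it.

For the measured compounds named here, compound 2 `CCSc1cc(C)c(C(=O)N=C(N)N)cc1S(C)(=O)=O` holds the lowest of the two numbers measured so far: in a functional assay for inhibition of sodium/hydrogen exchanger (Oryctolagus cuniculus) (a lower number here means a stronger inhibitor, a higher number a weaker inhibitor), compound 2 gives 5.9 nM, while compound 1 `Cc1cc(Br)c(S(C)(=O)=O)cc1C(=O)N=C(N)N` gives 12 nM, the difference being a 2.0-fold lower number from compound 1 to compound 2 (0.31 log units; beyond the scatter). Compound 3 `COc1cc(C)c(C(=O)N=C(N)N)cc1S(C)(=O)=O` keeps the shared core and differs from compound 2 in one place: methoxy in place of ethylsulfanyl on an aromatic carbon. Going by the values given here, no measured step swaps these two groups, so the only guide is that one replacement on an aromatic carbon moved the number only modestly. A step of about a 1.7-fold higher number from compound 2 to compound 3 (0.23 log units; within the scatter) is therefore expected, a slight weakening. Compound 3 is estimated at 10 nM, within 3.5 nM to 30 nM.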

Compound 3, half-maximal inhibitory concentration: 16 nM
Beside the measured number, compound 3's estimate is 1.6-fold (0.20 log units) below it; low and high end bracket the measured number.
By their numbers in this assay, from the lowest: compound 2; then compounds 1 and 3 (each within the scatter of the next).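

Methoxy in place of ethylsulfanyl in this assay gives a step beyond the scatter (a 2.7-fold higher number from compound 2 to compound 3 (0.43 log units; beyond the scatter)), so ethylsulfanyl now stands ahead of two different groups at this position. Methoxy in place of bromo gives a step within the scatter (a 1.3-fold higher number from compound 1 to compound 3 (0.12 log units; within the scatter)), so those two groups cannot be told apart here. Nothing available explains why the numbers fall this way. Still open, on these data alone, is whether a longer chain such as propylsulfanyl, or an amine, at this position would give a lower number than ethylsulfanyl.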